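The source may report more compounds than this note shows. Statements on the series, on what has been measured and on what is new or still open speak of the compounds shown alone.

Measured compounds:
- compound 1 `COc1ccc2cccc(CCCC(N)=O)c2c1`: in an assay (Ovis aries) for binding affinity to melatonin receptor type 1A (Homo sapiens) (on this read-out lower numbers stand for stronger inhibition and higher numbers for weaker inhibition), compound 1 gives 20 nM
- compound 2 `COc1ccc2c(c1)OC(CNC(C)=O)=C(c1ccccc1)O2`: in this assay compound 2 gives 10000 nM
- compound 3 `COc1ccc2c(c1)C=C(CNC(C)=O)CO2`: in this assay compound 3 gives 15800 nM

Compound 3 stands at the highest number of the three, that is, at the weak end. Its value and that of compound 2 lie within the usual scatter of each other, so no order can be read between them; compound 1 gives a far lower number, a gap well beyond the scatter.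

Compound 4 `CCCC(=O)NCC1=Cc2cc(OC)ccc2OC1` has not been measured. It differs from compound 3 in one place: ethyl in place of hydrogen on a saturated chain carbon bound to a carbonyl carbon. Among the measured compounds shown here, no pair of measured compounds differs by this same change, so there is no measured step to lean on. What is expected is a modest step in this assay, more likely toward a lower number than a higher one, though it may still fall within the scatter. The step from compound 3 to compound 4 is estimated as a 2.6-fold lower number from compound 3 to compound 4 (0.42 log units; beyond the scatter). Compound 4 is therefore expected to give about 6000 nM, with a plausible range from 1500 nM to 20000 nM.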

Compound 4, half-maximal inhibitory concentration: 20 nM
Compound 4: middle estimate off by 300-fold (2.48 log units), on the high side; the whole stated range lies above it.
By their numbers in this assay, from the lowest: compounds 1 and 4 (each within the scatter of the next); then compounds 2 and 3 (each within the scatter of the next).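

At this position the change is anything but minor: in this assay, ethyl in place of hydrogen on a saturated chain carbon bound to a carbonyl carbon gives a 790-fold lower number from compound 3 to compound 4 (2.90 log units; beyond the scatter) with no change elsewhere in the molecule. Among the compounds shown here, this is the first step between compounds differing in one place, and it shows that turning acetamido into (propylcarbonyl)amino, an addition of just 2 heavy atoms, can move the number far beyond the scatter. Nothing available explains why so small a change has so large an effect.

Only acetyl and propylcarbonyl are shown here, so it remains open whether a longer chain such as butylcarbonyl, or a ring such as cyclopropylcarbonyl, would lower the number further or raise it again. Also open, from the compounds shown here alone, is whether the same change would have a similar effect on the core of compound 2, which carries the same acetamido group.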